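A few compounds are considered here, and "the series" means these few. Any claim that something is new, unique, unknown or untested is made for them only; others in the source may bear on it.

Compound 2 `COc1ccc(S(=O)(=O)NC2=NCCN2C(=S)SN2CCn3c2nsc3=S)cc1OC` keeps the shared core of compound 1 `COc1cc(C)ccc1S(=O)(=O)NC1=NCCN1C(=S)SN1CCn2c1nsc2=S` and differs from it only on the sulfonyl sulfur. In a functional assay on KYSE-510 cells (Homo sapiens) for antiproliferative activity, read by crystal violet staining, with a stated time of 96 h (a higher number here means a weaker inhibitor of growth, a lower number a stronger inhibitor of growth), compound 1 gives >= 20000 nM, which is a limit of the assay and not a number. In this assay compound 2 gives >= 20000 nM, likewise a limit. Among the measured compounds shown here, the single step measured so far, a step that the two limits leave unreadable from compound 1 to compound 2, therefore cannot be read in size or direction. Compound 2 thus stands at the limit, with nothing measured that places it above or below any other compound. Compound 3 `O=S(=O)(NC1=NCCN1C(=S)SN1CCn2c1nsc2=S)c1ccc(Cl)cc1Cl` is not yet measured; it differs from compound 2 by 2,4-dichlorophenyl in place of 3,4-dimethoxyphenyl on a sulfonyl sulfur. For the measured compounds named here, no measured step bears on this change, since both values shown sit at a limit, (the limit of >= 20000 nM in this assay, at which 2 of the 2 values shown sit), and no step size beyond the scatter can be drawn from them in this assay. Compound 3 is expected to stay at the limit as well, the expected step that the limit leaves unreadable from compound 2 to compound 3 being essentially flat. The estimate for compound 3 in this assay is 25000 nM, within 12000 nM to 60000 nM.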

Compound 3, concentration for 50% growth inhibition: >= 20000 nM
Compound 3: no number, only a limit; the forecaster's own chance of this, stated with the estimate: 80%; the middle value does not contradict the limit.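

Compound 3 also sits at a limit of the assay, so no step among compound 1, compound 2 and compound 3 can be read in this assay: the limit of >= 20000 nM in this assay, at which 3 of the 3 values shown sit.

The compounds shown leave open whether any group on the sulfonyl sulfur brings growth inhibition into the measurable range.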